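A few compounds are considered here, and "the series" means these few. Any claim that something is new, unique, unknown or untested is made for them only; others in the source may bear on it.

Compound 1 `CCOC(=O)C1=C(NN=C(C(C)=O)C(C)=O)Nc2[nH]nc(C)c2C1c1ccc(N(C)C)cc1` is one of two compounds already measured in a functional assay on MCF7 cells (Homo sapiens) for inhibition, read by MTT assay, with a stated time of 48 h; on this read-out lower numbers stand for stronger inhibition and higher numbers for weaker inhibition; in this assay compound 1 gives 9740 nM. Among the measured compounds shown here, its only measured neighbour is compound 2 `CCOC(=O)C1=C(NN=C(C#N)C#N)Nc2[nH]nc(C)c2C1c1ccc(N(C)C)cc1`, which in this assay gives 12100 nM, and the step of a 1.2-fold higher number from compound 1 to compound 2 (0.09 log units; within the scatter) shows that the two numbers cannot be told apart. Compound 3 `CCOC(=O)C1=C(N/C=N/c2ccc(C)cc2)Nc2[nH]nc(C)c2C1c1ccc(N(C)C)cc1` differs from compound 1 at the same place: a group of 9 heavy atoms (8 carbon, 1 nitrogen; one six-membered aromatic ring of carbon only) in place of a group of 8 heavy atoms (5 carbon, 1 nitrogen, 2 oxygen; no ring), on an amine nitrogen. For the measured compounds named here, the only step that bears on this change is the one from compound 1 to compound 2, where a different replacement on the same amine nitrogen left the read-out within the scatter. Going by the values given here, with one within-scatter step as the sole guide, no step beyond the scatter is expected for compound 3 in this assay, and the expected step of a 1.0-fold lower number from compound 1 to compound 3 (0.01 log units; within the scatter) is accordingly small. Compound 3 is therefore estimated at 9500 nM, with a range from 3000 nM to 30000 nM.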

Compound 3, half-maximal inhibitory concentration: 50500 nM
For compound 3 the middle estimate is 5.3-fold (0.73 log units) below the measured one, outside the stated range (above it).
By their numbers in this assay, from the lowest: compounds 1 and 2 (each within the scatter of the next); then compound 3.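

The earlier pair left this amine nitrogen looking indifferent to replacement, but in this assay the group carrying one six-membered aromatic ring of carbon only gives a 5.2-fold higher number from compound 1 to compound 3 (0.71 log units; beyond the scatter) and a 4.2-fold higher number from compound 2 to compound 3 (0.62 log units; beyond the scatter) on the same nitrogen. Both steps are beyond the scatter and run the same way, so the read-out here does depend on which group is attached. Compounds 1 and 2, both with ring-free groups, stand within the scatter of each other, and compound 3 alone gives the higher number. No measurement shown accounts for this difference.

The entering group differs from the two ring-free groups in more than its ring, so the compounds shown do not tie the step to the aromatic ring itself. As far as these compounds go, how a cyclohexyl ring, a plain phenyl group or a short alkyl chain on this nitrogen would read remains open.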